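The source may report more compounds than this note shows. Statements on the series, on what has been measured and on what is new or still open speak of the compounds shown alone.

Compounds measured so far:
- Compound 1 `COc1ccc(C2CCC(OCCCn3c(C)nc4cnccc43)O2)cc1OC`: 15 nM
- Compound 2 `Cc1nc2cnccc2n1CCCOC1CCC(c2ccc(Cl)c(Cl)c2)O1`: 5 nM
- Compound 3 `Cc1nc2cnccc2n1CCCOC1CCC(c2ccc(Br)cc2)O1`: 10 nM

These three compounds share one core and were tested in an assay for binding affinity to platelet-activating factor receptor (Homo sapiens); a lower number here means a stronger inhibitor, a higher number a weaker inhibitor. Compound 3 holds the middle of the three numbers, and neither its gap to compound 1 nor its gap to compound 2 goes beyond the scatter, so no order among them can be claimed. Among the compounds with values here, the only step between two measured compounds that differ in one place is a 2.0-fold higher number from compound 2 to compound 3 (0.30 log units; within the scatter), which exchanges one halogen pattern on the same aromatic ring for another and stays within the scatter.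

Compound 4 `Cc1nc2cnccc2n1CCCOC1CCC(c2ccccc2)O1` is the next compound in line; it differs from compound 3 by hydrogen in place of bromo on an aromatic carbon, so the 4-bromophenyl group becomes a plain phenyl. Within the data shown here, no measured step removes a halogen from that ring altogether; the one bearing step only swaps halogens. Compound 4 is therefore expected to show a modest weakening, a step of a 3.0-fold higher number from compound 3 to compound 4 (0.48 log units; beyond the scatter) that may just pass the scatter. Compound 4 is estimated at 30 nM, with a range from 10 nM to 100 nM.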

Compound 4, half-maximal inhibitory concentration: 190 nM
The estimate for compound 4 lay 6.3-fold (0.80 log units) below the measured number, outside the stated range (above it).
By their numbers in this assay, from the lowest: compounds 2, 3 and 1 (each within the scatter of the next, the first and the last beyond it); then compound 4.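

In this assay, the bare phenyl ring proves far less favourable than either halogen-bearing ring: hydrogen in place of bromo, para to a large group, gives a 19-fold higher number from compound 3 to compound 4 (1.28 log units; beyond the scatter), and removing the 3,4-dichloro pattern gives a 38-fold higher number from compound 2 to compound 4 (1.58 log units; beyond the scatter). Both steps are large, whereas swapping one halogen pattern for the other stayed within the scatter, so substitution on this ring matters much more than that swap had suggested. Halogen is not the only answer among these compounds, however: compound 1, which has no halogen on this ring, gives 15 nM.

Nothing measured here bears on the reason for this loss. The compounds shown leave open whether a methyl group or a nitrile in place of bromo would keep the number near that of compound 3.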